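The source may hold more compounds than are shown below. What is called first, only, known or untested is meant among the compounds shown, and "the series" means these compounds.

Of the compounds shown here, three of a shared core have been measured so far. Compound 1 `COc1ccc(S(=O)(=O)c2ccccc2)c(Cc2c3c(n(CC(=O)O)c2C)CCNC3=O)c1` gives 3.6 nM in a functional assay on CHO.K1 cells for antagonist activity at prostaglandin D2 receptor 2 (Homo sapiens), read by GTPgammaS binding, with a stated time of 1 h; on this read-out lower numbers stand for stronger inhibition and higher numbers for weaker inhibition. Compound 2 `COc1cccc(S(=O)(=O)c2ccccc2Cc2c3c(n(CC(=O)O)c2C)CCNC3=O)c1` gives 12 nM in this assay, the second highest of the three numbers, with compound 1 beyond the scatter on the lower side and compound 3 further away on the higher side. Compound 3 `Cc1c(Cc2ccc(S(=O)(=O)c3ccccc3)cc2)c2c(n1CC(=O)O)CCNC2=O` gives 170 nM in this assay.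

Compound 4 `Cc1c(Cc2ccccc2-c2cccc3ccccc23)c2c(n1CC(=O)O)CCNC2=O` has not yet been measured. It differs from compound 2 in one place: naphthalen-1-yl in place of (3-methoxyphenyl)sulfonyl on an aromatic carbon. Among the measured compounds shown here, no single-change step between measured compounds is available, so the expected size rests on this change alone. Compound 4 is expected to move toward higher numbers in this assay, by a moderate step of a 5.0-fold higher number from compound 2 to compound 4 (0.70 log units; beyond the scatter). Compound 4 is estimated at 60 nM, within a range from 15 nM to 300 nM.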

Compound 4, half-maximal inhibitory concentration: 480 nM
The estimate for compound 4 lay 8.0-fold (0.90 log units) below the measured number; measured number above the stated range.
By their numbers in this assay, from the lowest: compound 1; then compound 2; then compound 3; then compound 4.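

In this assay, naphthalen-1-yl in place of (3-methoxyphenyl)sulfonyl on this aromatic carbon, ortho to a large group, gives a large loss of inhibition, a 40-fold higher number from compound 2 to compound 4 (1.60 log units; beyond the scatter), so this position does not take every large aromatic group alike. The group that leaves carries sulfur, oxygen and hydrogen-bond acceptors, while the one that enters is carbon only, and no measurement here accounts for the step. From the compounds shown here alone, whether the sulfonyl link or the fused ring matters more stays open. A phenyl or benzoyl group on the same carbon would help separate the two.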